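Removing a fluorine from compound 1: permeability outlook

This account rests on a few compounds, and the source may have more. Where it says the series, first, only, none or still open, it means among the compounds named here.

Compound 1 `Fc1ccc(-c2ccc3c(NCCCNCc4ccco4)ccnc3c2)cc1`: in an ADME assay for permeability, using PAMPA, with a stated time of 30 min, at pH 7.4 (on this read-out lower numbers stand for lower permeability and higher numbers for higher permeability), compound 1 gives 237 10^-6 cm/s
Compound 2 `COc1cccc(CNCCCNc2ccnc3cc(-c4ccc(F)cc4)ccc23)c1O`: in this assay compound 2 gives 237 10^-6 cm/s
Compound 3 `COc1ccc(F)cc1CNCCCNc1ccnc2cc(Cc3ccccc3)ccc12`: in this assay compound 3 gives 23 10^-6 cm/s

Compound 1 stands level with compound 2 at the digits shown, and together they are the highest of the three; compound 3 sits well below, a gap that lies beyond the scatter. Compound 4 `c1ccc(-c2ccc3c(NCCCNCc4ccco4)ccnc3c2)cc1` differs from compound 1 by hydrogen in place of fluoro on an aromatic carbon. Among the compounds with values here, the only measured step, no change at the digits printed from compound 1 to compound 2 (within the scatter), concerns a different part of the molecule, so nothing measured speaks directly to exchanging fluoro for hydrogen here. No step beyond the scatter is expected in this assay. Compound 4 is estimated at 210 10^-6 cm/s, within 110 10^-6 cm/s to 400 10^-6 cm/s. The expected step, a 1.1-fold lower number from compound 1 to compound 4 (0.05 log units; within the scatter), is thus expected to stay within the scatter.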

Compound 4, apparent permeability: 237 10^-6 cm/s
The estimate for compound 4 lay 1.1-fold (0.05 log units) below the measured number; low and high end bracket the measured number.
By their numbers in this assay, from the lowest: compound 3; then compounds 1, 2 and 4 (each within the scatter of the next).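

In this assay, within the data shown here, replacing the fluoro with hydrogen gives no change at the digits printed from compound 1 to compound 4 (within the scatter), the first direct reading of a change at this position. For this one pair, 4-fluorophenyl and phenyl cannot be told apart on this read-out. No measurement shown here bears on why the number holds.

On these data alone, whether an amine, a methoxy group or a carboxylic acid on that same aromatic carbon would also leave the number in place remains open. So does whether the same change reads alike in compounds carrying another group in place of furan-2-yl.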